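Swapping a Hydroxyphenyl for a Trimethoxyphenyl on the Core

A few compounds are considered here, and "the series" means these few. Any claim that something is new, unique, unknown or untested is made for them only; others in the source may bear on it.

Compound 1 `Cc1cc(O)c(C2=NN(c3ccc(S(N)(=O)=O)cc3)C(c3ccccc3O)C2)cc1Cl` was tested in a functional assay on OVCAR-8 cells (Homo sapiens) for antiproliferative activity, with a stated time of 48 h (on this read-out lower numbers stand for higher toxicity in this test and higher numbers for lower toxicity in this test), and gave 91800 nM. Within the data shown here, that is the only plain number in this set. Compound 2 `Cc1cc(O)c(C2=NN(c3ccc(S(N)(=O)=O)cc3)C(c3ccccc3Cl)C2)cc1Cl` differs from compound 1 in one place only. In this assay compound 2 gives > 100000 nM, which is a limit of the assay and not a number. The step of an at least 1.0-fold higher number from compound 1 to compound 2 (0.03 log units; that floor lies within the scatter) accordingly shows nothing beyond the usual scatter, and one of the two results sits at the limit of > 100000 nM in this assay, at which 1 of the 2 values shown sits.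

Compound 3 `COc1ccc(C2CC(c3cc(Cl)c(C)cc3O)=NN2c2ccc(S(N)(=O)=O)cc2)c(OC)c1OC` carries a different change on the same core: 2,3,4-trimethoxyphenyl in place of 2-hydroxyphenyl on a saturated ring carbon. Among the measured compounds shown here, no measured step touches this group in the same way; the only step measured so far, from hydroxy to chloro on an aromatic carbon, stayed within the scatter. For the measured compounds named here, with that as the sole guide, the expected step is a 1.3-fold lower number from compound 1 to compound 3 (0.12 log units; within the scatter), small and in no clear direction. Compound 3 is therefore estimated at 70000 nM in this assay, with a range from 20000 nM to 250000 nM, and a fair chance that only a limit is reported again.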

Compound 3, concentration lethal to 50% of the cells: 68600 nM
For compound 3 the middle estimate is 1.0-fold (0.01 log units) above the measured one; the range from low to high includes it.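

Among these compounds, replacing 2-hydroxyphenyl with 2,3,4-trimethoxyphenyl, which has more heavy atoms, more hydrogen-bond acceptors and no hydrogen-bond donor, gives the first comparison at this saturated ring carbon in which both results are plain numbers: in this assay the step is a 1.3-fold lower number from compound 1 to compound 3 (0.13 log units; within the scatter), so this change cannot be told apart from the usual scatter. Compound 2 stays at a limit of the assay, not a number, with > 100000 nM. The step of an at least 1.4-fold lower number from compound 2 to compound 3 (0.16 log units; that floor lies within the scatter) is therefore only a floor and shows no real difference, because the value for compound 2 sits at the ceiling of the test: the limit of > 100000 nM in this assay, at which 1 of the 3 values shown sits.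

The three groups compared at this carbon do not show whether anything placed here can move the result beyond the scatter, and they do not separate the effect of removing the hydroxy group from that of adding the methoxy groups. A phenyl ring carrying an amine or a carboxylic acid, or a single methoxy group in place of the three, would be needed to test this position further.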